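Moving the trifluoromethyl group around the phenyl ring

This account rests on a few compounds, and the source may have more. Where it says the series, first, only, none or still open, it means among the compounds named here.

Compound 1 `Oc1cc(C(F)(F)F)ccc1-c1nc(-c2ccccc2O)n(-c2ccc(C(F)(F)F)cc2)n1` and compound 2 `Oc1cc(C(F)(F)F)ccc1-c1nc(-c2ccccc2O)n(-c2ccccc2C(F)(F)F)n1` share one core and differ only in where a trifluoromethyl group sits on the phenyl ring attached to an aromatic nitrogen. In a functional assay on PC-12 cells (Rattus norvegicus) for cytotoxicity, read by MTT assay, with stated times of 2 h and 24 h, tested at 10 uM (a lower number here means a weaker effect, a higher number a stronger effect of the compound at the concentration tested), compound 1 gives 102%, and compound 2 gives 92.2%; the two numbers lie within the usual scatter of each other, so neither can be called the stronger. Going by the values given here, the one step seen so far, a number 9.8 percentage points lower from compound 1 to compound 2 (within the scatter), shows that moving the trifluoromethyl group on this phenyl ring left this assay unchanged beyond its scatter. Compound 3 `Oc1cc(C(F)(F)F)ccc1-c1nc(-c2ccccc2O)n(-c2cccc(C(F)(F)F)c2)n1` carries the change (3-(trifluoromethyl)phenyl in place of 2-(trifluoromethyl)phenyl on an aromatic nitrogen), again a move of the same group on the same ring. Because the step of a number 9.8 percentage points lower from compound 1 to compound 2 (within the scatter) was within the scatter, no shift beyond the scatter is expected here either, and the step of a number 2.8 percentage points higher from compound 2 to compound 3 (within the scatter) is expected to be small. Compound 3 is therefore estimated at 95%, within a range from 80% to 108%.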

Compound 3, a percentage reported as activity, at one concentration (the size of the read-out at that concentration, not a potency): 99.9%
The estimate for compound 3 lay 4.9 percentage points below the measured number; measured number inside the range.
By their numbers in this assay, from the lowest: compounds 2, 3 and 1 (each within the scatter of the next).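

With compound 3, all three placements of the group have now been seen in this assay, as 2-(trifluoromethyl)phenyl, 3-(trifluoromethyl)phenyl and 4-(trifluoromethyl)phenyl on the same aromatic nitrogen. The new data show a number 7.7 percentage points higher from compound 2 to compound 3 (within the scatter) and a number 2.1 percentage points lower from compound 1 to compound 3 (within the scatter), so this read-out cannot tell any of the three placements apart, whereas the earlier pair covered only two of them. No information is available that would explain this result.

The compounds shown leave open whether a different group on this phenyl ring, such as an amine or a carboxylic acid, would shift the number beyond the scatter. They also leave open what would happen if the phenyl ring on this nitrogen gave way to a simple chain such as butyl.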